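Benzoyl for methylpyridinylcarbonyl on the shared core

The source may report more compounds than this note shows. Statements on the series, on what has been measured and on what is new or still open speak of the compounds shown alone.

Measured compounds in an ADME assay on HEK-293T cells (Homo sapiens) for cytotoxicity, read by MTT assay, with a stated time of 24 h; on this read-out higher numbers stand for lower toxicity in this test and lower numbers for higher toxicity in this test:
compound 1 `Cc1cncc(C(=O)n2c(-c3cn(-c4ccccc4)nc3-c3ccc(F)cc3)nc3ccccc32)c1` gives 119000 nM
compound 2 `Cc1ccc(-c2nn(-c3ccccc3)cc2-c2nc3ccccc3n2C(=O)c2cncc(C)c2)cc1` gives 155000 nM

Compound 1 stands alongside compound 2 with no separation beyond the scatter: the step of a 1.3-fold higher number from compound 1 to compound 2 (0.11 log units; within the scatter). Compound 3 `O=C(c1ccccc1)n1c(-c2cn(-c3ccccc3)nc2-c2ccc(F)cc2)nc2ccccc21` is not yet measured; it differs from compound 1 by phenyl in place of 5-methylpyridin-3-yl on a carbonyl carbon. Among the measured compounds shown here, no measured step touches the group on the carbonyl carbon; the only step at hand, a 1.3-fold higher number from compound 1 to compound 2 (0.11 log units; within the scatter), concerns the fluoro group and stays within the scatter. For compound 3 in this assay no step beyond the scatter is therefore expected, a 1.1-fold lower number from compound 1 to compound 3 (0.03 log units; within the scatter). The estimate for compound 3 is 110000 nM, with a range of 55000 nM to 230000 nM.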

Compound 3, half-maximal cytotoxic concentration: 180000 nM
Estimate against measurement, compound 3: 1.6-fold (0.21 log units) below, within the range that was stated.
By their numbers in this assay, from the lowest: compounds 1, 2 and 3 (each within the scatter of the next).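

In this assay, the group on the carbonyl carbon now has its first measured step: phenyl in place of 5-methylpyridin-3-yl gives a 1.5-fold higher number from compound 1 to compound 3 (0.18 log units; within the scatter) and stays within the scatter. Exchanging this pyridine-type ring for an all-carbon ring therefore gives no separable difference in this compound pair. No available evidence bears on this result.

On these data alone, whether an amine or a carboxylic acid on the phenyl ring would give a step beyond the scatter remains open. The same holds for a non-aromatic group, such as a piperidine, on the carbonyl carbon.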